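Lengthening the Chain of a Weak Inhibitor

The source may hold more compounds than are shown below. What is called first, only, known or untested is meant among the compounds shown, and "the series" means these compounds.

In an ADME assay on HEK293 cells (Homo sapiens) for inhibition, read by MTT assay, with stated times of 18 h and 4 h (a lower number here means a stronger inhibitor, a higher number a weaker inhibitor), compound 1 (`CCCCCCCCCCOP(=O)(O)OCCSC(=S)N1CCCC1`) gives > 100000 nM, which is a limit and not a number. Compound 2 (`CCCCCCCCCCOP(=O)(O)OCCSC(=S)N1CCN(C)CC1`) gives > 100000 nM, the same limit. Compound 3 (`CCCCCCCCCCOP(=O)(O)OCCSC(=S)N1CCCCC1`) gives an actual number, 70700 nM. Compound 4 (`CCCCCCCCCCCCCCCCOP(=O)(O)OCCSC(=S)N1CCCC1`) keeps the core of compound 1 and changes only the chain: hexyl in place of hydrogen on a saturated chain carbon, ten or more bonds along the chain from an oxygen on an unsaturated carbon. The two readable steps, an at least 1.4-fold lower number from compound 1 to compound 3 (0.15 log units; that floor lies within the scatter) and an at least 1.4-fold lower number from compound 2 to compound 3 (0.15 log units; that floor lies within the scatter), swap the group on the thiocarbonyl carbon and leave the chain alone, so they guide this change only weakly. A modest move toward a lower number is expected, with the estimated step being an at least 2.0-fold lower number from compound 1 to compound 4 (0.30 log units; that floor lies within the scatter). A further limit remains possible. For compound 4, the estimate is 50000 nM, within a range of 12000 nM to 150000 nM.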

Compound 4, half-maximal inhibitory concentration: > 100000 nM
Compound 4 ended at the assay's limit; the forecaster's own chance of this, stated with the estimate: 35%; at least 2.0-fold (0.30 log units) between middle value and limit.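

Compound 1 and compound 4 each give only a limit and no number, so no step between them can be read, because both stop at the same point: the limit of > 100000 nM in this assay, at which 3 of the 4 values shown sit.

As far as these compounds go, whether adding hexyl changes inhibition at all, and in which direction, stays open.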